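Swapping hydroxymethyl for methoxymethyl on the outer ring

The compounds below may be only part of what the source reports. "The series", "measured", "known", "first", "only" and "open" are said of these compounds alone.

Measured compounds:
- compound 1, `CC[C@@H](Nc1c(C#N)c(-c2ccc(-c3cccnc3C)cc2)nc2cnccc12)C(N)=O`: 1.9
- compound 2, `CC[C@@H](Nc1c(C#N)c(-c2ccc(-c3ccccc3OC)cc2)nc2cnccc12)C(N)=O`: 2.7
- compound 3, `CC[C@@H](Nc1c(C#N)c(-c2ccc(-c3cccc(CO)c3)cc2)nc2cnccc12)C(N)=O`: 2

All three share one core and differ only in the outer aromatic group. In a physicochemical assay for lipophilicity, read by HPLC, at pH 7.5 (on this read-out higher numbers stand for higher lipophilicity and lower numbers for lower lipophilicity), compound 3 gives 2, the second highest of the three numbers. Its nearest neighbour is compound 1, and a number 0.10 log units higher from compound 1 to compound 3 (within the scatter), so these two cannot be told apart. The clear outlier is compound 2, since a number 0.70 log units lower from compound 2 to compound 3 (beyond the scatter).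

The unmeasured compound 4, `CC[C@@H](Nc1c(C#N)c(-c2ccc(-c3ccccc3COC)cc2)nc2cnccc12)C(N)=O`, changes the same position once more: 2-(methoxymethyl)phenyl in place of 3-(hydroxymethyl)phenyl on an aromatic carbon. The entering group has no hydrogen-bond donors, where the leaving group has one, and it carries one more carbon.

Among the compounds with values here, the step that bears most on this is the one to compound 2: a number 0.70 log units lower from compound 2 to compound 3 (beyond the scatter), that is, the number fell when a donor-free methoxy-bearing ring gave way to the hydroxymethyl-bearing ring. Compound 4 again has a donor-free ring, now with a methoxymethyl group, so a step of similar size back upward is expected, a number 0.80 log units higher from compound 3 to compound 4 (beyond the scatter). For compound 4 the estimate in this assay is therefore 2.8, with a likely range from 2.4 to 3.2.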

Compound 4, distribution coefficient: 2.6
Estimate against measurement, compound 4: 0.20 log units above, and the stated range covers the measured number.
By their numbers in this assay, from the lowest: compounds 1 and 3 (each within the scatter of the next); then compounds 4 and 2 (each within the scatter of the next).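

In this assay the change from 3-(hydroxymethyl)phenyl to 2-(methoxymethyl)phenyl gives a number 0.60 log units higher from compound 3 to compound 4 (beyond the scatter) and the same group, set against 2-methylpyridin-3-yl, gives a number 0.70 log units higher from compound 1 to compound 4 (beyond the scatter) so this position can carry a longer group and still sit with the higher numbers of the set. Methoxymethyl in place of methoxy gives a number 0.10 log units lower from compound 2 to compound 4 (within the scatter) which means that compound 2 and compound 4 cannot be told apart on this read-out, even though their groups differ by more than the simple swap of one substituent for another might suggest. Nothing shown offers a measured reason for any of these steps.

Going by these compounds, the step from compound 3 to compound 4 changes three things at once, since the hydrogen-bond donor goes, a carbon comes in and the group takes a different place on the outer ring, so the share of each stays open until 2-(hydroxymethyl)phenyl and 3-(methoxymethyl)phenyl can be compared with these compounds. On these data alone, how an amine such as 2-(aminomethyl)phenyl, or a carboxylic acid, would read at this position also remains open.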